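The source may hold more compounds than are shown below. What is called first, only, known or untested is meant among the compounds shown, and "the series" means these compounds.

Measured so far in an in vitro assay on HEK385-7 cells for displacement of a labelled ligand from prostaglandin D2 receptor 2 (Homo sapiens); a higher number here means a weaker inhibitor, a lower number a stronger inhibitor:
compound 1 `COc1ccc(C(c2ccccn2)c2nc(-c3ccc(Cl)cc3)c(CC(=O)O)s2)cc1`: 61 nM
compound 2 `O=C(O)Cc1sc(C(c2ccccc2)c2ccccc2)nc1-c1ccccc1`: 570 nM
compound 3 `O=C(O)Cc1sc(C(c2ccccc2)c2ccccc2)nc1-c1ccc(F)cc1`: 8.7 nM

Compound 3 gives the lowest number of the three; compound 1 is the nearest of the others and compound 2 the furthest. Compound 4 `O=C(O)Cc1sc(C(c2ccccc2)c2ccccc2)nc1-c1cccc(F)c1` has not yet been measured. It differs from compound 3 by 3-fluorophenyl in place of 4-fluorophenyl on an aromatic carbon. Within the data shown here, the only measured step touching this ring is a 66-fold lower number from compound 2 to compound 3 (1.82 log units; beyond the scatter), which introduced the fluorine where there had been none. Among the measured compounds shown here, no measured pair shows the fluorine relocated on the ring, so that step is only a loose guide: part of the gain may be kept, part lost. Compound 4 is therefore expected to give a moderately higher number, a 3.4-fold higher number from compound 3 to compound 4 (0.54 log units; beyond the scatter), estimated at 30 nM with a range from 6 nM to 150 nM.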

Compound 4, half-maximal inhibitory concentration: 2.9 nM
The estimate for compound 4 lay 10-fold (1.01 log units) above the measured number; measured number below the stated range.
By their numbers in this assay, from the lowest: compound 4; then compound 3; then compound 1; then compound 2.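

The gain from fluorine does not depend on the 4-fluorophenyl arrangement: relocating the fluorine gives a 3.0-fold lower number from compound 3 to compound 4 (0.48 log units; beyond the scatter), so 3-fluorophenyl outperforms 4-fluorophenyl on this carbon next to the ring nitrogen. Measured against the unsubstituted phenyl, the step grows to a 200-fold lower number from compound 2 to compound 4 (2.29 log units; beyond the scatter), so both fluorine placements shown improve on hydrogen. No measurement available here accounts for the preference between the two placements. Still open, on these data alone, is whether the gain is specific to fluorine or would persist with a methyl, trifluoromethyl or nitrile in its place on 3-fluorophenyl.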